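Adding Methyl Groups to the Sulfonyl Aryl Ring

The source may report more compounds than this note shows. Statements on the series, on what has been measured and on what is new or still open speak of the compounds shown alone.

Among the compounds with values here, compound 3 `Cc1ccc(S(=O)(=O)N2CCN(c3ccc(C(=O)/C=C/c4ccccc4)cc3)CC2)cc1` stands highest of the three compounds measured so far in a functional assay on the whole organism (strain Kunming) for inhibition, with Mus musculus as the target, with a stated time of 1 h, at a dose of 40 mg/kg by the oral route (on this read-out higher numbers stand for more inhibition at the one dose given (going by the name of the read-out) and lower numbers for less inhibition), where compound 3 gives 30.8%. The two compounds carrying an aryl group directly on the amine nitrogen in a ring sit well below it: compound 1 `Cc1ccc(N2CCN(c3ccc(C(=O)/C=C/c4ccccc4)cc3)CC2)cc1` gives 2.85% and compound 2 `O=C(/C=C/c1ccccc1)c1ccc(N2CCN(c3ccccc3Cl)CC2)cc1` gives 4.71%. The measured steps are a number 28 percentage points higher from compound 1 to compound 3 (beyond the scatter) and a number 26.1 percentage points higher from compound 2 to compound 3 (beyond the scatter), whereas a number 1.9 percentage points higher from compound 1 to compound 2 (within the scatter). Compound 4 `Cc1cc(C)c(S(=O)(=O)N2CCN(c3ccc(C(=O)/C=C/c4ccccc4)cc3)CC2)c(C)c1` differs from compound 3 by 2,4,6-trimethylphenyl in place of 4-methylphenyl on a sulfonyl sulfur. Within the data shown here, none of the measured steps changes the group on the sulfonyl sulfur, so none bears directly on this change, and no step beyond the scatter is expected. The expected step is therefore a number 0.8 percentage points lower from compound 3 to compound 4 (within the scatter). Compound 4 is estimated to give 30%, within a range of 14% to 46%.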

Compound 4, a percentage reported as inhibition, in the whole organism at one dose (the size of the read-out at that dose, not a potency): 55.5%
Estimate against measurement, compound 4: 25.5 percentage points below; measured number above the stated range.
By their numbers in this assay, from the lowest: compounds 1 and 2 (each within the scatter of the next); then compound 3; then compound 4.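

The group on the sulfonyl sulfur matters as well: in this assay, 2,4,6-trimethylphenyl in place of 4-methylphenyl gives a number 24.7 percentage points higher from compound 3 to compound 4 (beyond the scatter), a gain in inhibition at the one dose tested. Within the data shown here, the earlier steps changed only the group on the amine nitrogen in a ring, so this is the first evidence that the aryl group on the sulfur can be varied with effect. Nothing here explains the rise.

Going by these compounds, it remains open whether a single added methyl would give part of this gain. On these data alone, it is equally open how a ring bearing chlorine or methoxy groups would compare.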